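Triazole aryl exchange in the phenol series

The source may report more compounds than this note shows. Statements on the series, on what has been measured and on what is new or still open speak of the compounds shown alone.

Compound 1 `C=C1C(=O)[C@]23C[C@@]1(O)CC[C@H]2c1ccc(OS(=O)(=O)c2ccc(C)cc2)c(C)c1[C@@H]3Cn1cc(-c2ccccn2)nn1` carries the (4-methylphenyl)sulfonyl ester on the phenolic oxygen; compound 2 `C=C1C(=O)[C@]23C[C@@]1(O)CC[C@H]2c1ccc(O)c(C)c1[C@@H]3Cn1cc(-c2ccccn2)nn1` is the free phenol of the same core. In a functional assay on A549 cells (Homo sapiens) for cytotoxicity, read by MTT assay, with a stated time of 4 days (a lower number here means a stronger inhibitor, a higher number a weaker inhibitor), compound 1 gives 2310 nM and compound 2 gives 1570 nM, so that a 1.5-fold lower number from compound 1 to compound 2 (0.17 log units; within the scatter). Compound 3 `Cc1c(O)ccc2c1[C@H](Cn1cc(-c3ccccn3)nn1)[C@@]13CC(=O)[C@@](C)(CC[C@@H]21)C3`, which keeps the pyridinyl-triazole arm on a different core, sits in this assay at > 20000 nM, a limit of the assay rather than a number, as noted in the limit of > 20000 nM in this assay, at which 1 of the 3 values shown sits. Among the two values that are numbers, compound 2 has the lowest one, with compound 1 within the scatter of it.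

Compound 4 `C=C1C(=O)[C@]23C[C@@]1(O)CC[C@H]2c1ccc(O)c(C)c1[C@@H]3Cn1cc(-c2ccc(C(F)(F)F)cc2)nn1` differs from compound 2 only at the triazole: 4-(trifluoromethyl)phenyl in place of pyridin-2-yl on an aromatic carbon. Going by the values given here, none of the measured steps touches this position; the only step with a number at both ends, from compound 1 to compound 2, concerns the phenolic oxygen and not the aryl on the triazole. Among the compounds with values here, there is thus no measured step that bears on the change to compound 4, and no direction can be read off for this assay; the default expectation is a step no larger than the scatter. Compound 4 is therefore expected at 1800 nM, with a range from 500 nM to 7000 nM, which is estimated to mean a 1.1-fold higher number from compound 2 to compound 4 (0.06 log units; within the scatter).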

Compound 4, half-maximal inhibitory concentration: 1110 nM
The estimate for compound 4 lay 1.6-fold (0.21 log units) above the measured number, and the stated range covers the measured number.
By their numbers in this assay, from the lowest: compounds 4, 2 and 1 (each within the scatter of the next, the first and the last beyond it). At a limit, above all of these: compound 3.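

Going by these compounds alone, this is the first measured change at the aromatic carbon of the five-membered aromatic ring with 3 nitrogen: in this assay, replacing pyridin-2-yl with 4-(trifluoromethyl)phenyl gives a 1.4-fold lower number from compound 2 to compound 4 (0.15 log units; within the scatter). The pair shows that, on this core, the ring nitrogen and the hydrogen-bond acceptor of pyridin-2-yl can leave and a group with more heavy atoms can enter without a step beyond the scatter, so this aryl position tolerates at least this one exchange in this assay. Nothing among the data shown offers an explanation for this outcome.

Only two aryl groups, both six-membered aromatic rings, are shown at this position, so it remains open whether an aliphatic amine, a carboxylic acid or a longer alkyl chain there would give a step beyond the scatter. Also open, from the compounds shown here alone, is whether the same exchange would read alike with the (4-methylphenyl)sulfonyl ester of compound 1 on the phenolic oxygen, or on the core of compound 3, whose value is a limit and not a number.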